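A halogenated phenyl swap on a shared core

The compounds below may be only part of what the source reports. "The series", "measured", "known", "first", "only" and "open" are said of these compounds alone.

Of the compounds shown here, two of one series have been measured in a physicochemical assay, with a stated time of 90 min; a higher number here means that more compound is needed for the effect, a lower number that less compound is needed. Compound 1 `C/C(=N\N=C1/SCC(=O)N1Cc1cccc(Cl)c1)c1ccccn1` gives 2040000 nM. Compound 2 `C/C(=N\N=C1/SCC(=O)N1Cc1ccccc1F)c1cccs1` gives 1260000 nM, the lower of the two numbers, though the gap to compound 1 lies within the usual scatter, so no order between them can be read. Compound 3 `C/C(=N\N=C1/SCC(=O)N1Cc1cccc(Cl)c1)c1cccs1` has not yet been measured. It differs from compound 2 in one place: 3-chlorophenyl in place of 2-fluorophenyl on a saturated chain carbon bound to an amide-type nitrogen in a ring. Among the measured compounds shown here, no measured pair isolates this change, so the size of the step is open. Because compound 1, which carries the same 3-chlorophenyl group, gives 2040000 nM, compound 3 is expected to sit close to both measured compounds, with a step of a 1.3-fold higher number from compound 2 to compound 3 (0.10 log units; within the scatter) that stays within the scatter. The estimate for compound 3 in this assay is 1600000 nM, with a range from 600000 nM to 4500000 nM.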

Compound 3, half-maximal effective concentration: 1160000 nM
Estimate against measurement, compound 3: 1.4-fold (0.14 log units) above; the measured number falls inside the stated range.
By their numbers in this assay, from the lowest: compounds 3, 2 and 1 (each within the scatter of the next).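

In this assay, the swap to 3-chlorophenyl in place of 2-fluorophenyl on a saturated chain carbon bound to an amide-type nitrogen in a ring now has a measured size: a 1.1-fold lower number from compound 2 to compound 3 (0.04 log units; within the scatter), so the two groups cannot be told apart at this position. Compound 3 also isolates the change to thiophen-2-yl in place of pyridin-2-yl on a carbon with a double bond to nitrogen, with a 1.8-fold lower number from compound 1 to compound 3 (0.25 log units; within the scatter), so no difference can be read at this second place either. No evidence bears on a cause for either step. As far as these compounds go, all three compounds carry a halogenated phenyl group, so it remains open whether an amine or a carboxylic acid on that phenyl ring would give a step beyond the scatter. The same question stands for a longer chain in place of the saturated chain carbon.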